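The compounds below may be only part of what the source reports. "The series", "measured", "known", "first", "only" and "open" are said of these compounds alone.

Among the compounds with values here, in a functional assay on LNCaP cells (Homo sapiens) for cytotoxicity, read by MTT assay, with a stated time of 72 h (on this read-out higher numbers stand for weaker inhibition and lower numbers for stronger inhibition), two compounds have numbers so far. Compound 1, `CC1=CCCC(C)(C)C1/C=C/C(=O)/C=C/c1cccc([N+](=O)[O-])c1`, gives 3300 nM, and compound 2, `CC1=C(/C=C/C(=O)/C=C/c2ccccc2)C(C)(C)CCC1O`, gives 5800 nM. These values lie within the usual scatter of each other, so compound 2 cannot be ranked apart from compound 1. Their structures also differ in more than one place, so the pair does not show what any single change does.

The next compound, compound 3, `CC1=C(/C=C/C(=O)/C=C/c2ccccc2C(F)(F)F)C(C)(C)CCC1O`, differs from compound 2 in one place: trifluoromethyl in place of hydrogen on an aromatic carbon. Trifluoromethyl stands in place of hydrogen on an aromatic carbon, ortho to a large group. Within the data shown here, no measured pair here shows the effect of this replacement, so any forecast is uncertain. A small move towards stronger inhibition in this assay is expected, one that stays within the scatter, although a move the other way cannot be ruled out. The estimated step is a 1.7-fold lower number from compound 2 to compound 3 (0.22 log units; within the scatter). Compound 3 is expected to give about 3500 nM, with an estimated range from 1300 nM to 9000 nM.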

Compound 3, half-maximal inhibitory concentration: 2900 nM
Estimate against measurement, compound 3: 1.2-fold (0.08 log units) above; low and high end bracket the measured number.
By their numbers in this assay, from the lowest: compounds 3, 1 and 2 (each within the scatter of the next).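

Trifluoromethyl in place of hydrogen on an aromatic carbon, ortho to a large group, is the first single change that can be read in this assay, and it amounts to a 2.0-fold lower number from compound 2 to compound 3 (0.30 log units; within the scatter). The earlier pair of compounds differed in more than one place and could say nothing about any one change, whereas this step concerns this position alone and shows that a group of 4 heavy atoms can replace a hydrogen atom there while the number stays within the scatter of that of the parent compound. Nothing measured here bears on what lies behind this small step, so the result records only its size and not its origin.

As far as these compounds go, a single group at a single position cannot show a trend, so it remains open whether a smaller or a different substituent at this carbon, such as fluorine, methoxy, an amine or a carboxylic acid, would give a step beyond the scatter. Within the data shown here, it also remains open whether trifluoromethyl would behave the same way on another carbon of this aromatic ring, or on a core other than the one shared by compound 2 and compound 3.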